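From pyridin-3-yl to 2-chloropyridin-3-yl

A few compounds are considered here, and "the series" means these few. Any claim that something is new, unique, unknown or untested is made for them only; others in the source may bear on it.

Among the measured compounds shown here, in a physicochemical assay for metabolic stability, read by HPLC (on this read-out higher numbers stand for a longer-lived compound and lower numbers for a shorter-lived compound), compound 3 `Cc1cn([C@H]2C[C@H](N=[N+]=[N-])[C@@H](COP(=O)(O)Oc3cccnc3)O2)c(=O)[nH]c1=O` gives 3.88 h, the lowest of the three numbers so far. Compound 1 `Cc1cn([C@H]2C[C@H](N=[N+]=[N-])[C@@H](COP(=O)(O)Oc3ccc(Br)cc3)O2)c(=O)[nH]c1=O`, which carries 4-bromophenyl, gives 7.97 h, and compound 2 `Cc1ccc(OP(=O)(O)OC[C@H]2O[C@@H](n3cc(C)c(=O)[nH]c3=O)C[C@@H]2N=[N+]=[N-])cn1`, which carries 6-methylpyridin-3-yl, gives 28.9 h.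

Compound 4 `Cc1cn([C@H]2C[C@H](N=[N+]=[N-])[C@@H](COP(=O)(O)Oc3cccnc3Cl)O2)c(=O)[nH]c1=O` has not yet been measured. It differs from compound 3 by chloro in place of hydrogen on an aromatic carbon, next to the ring nitrogen.

Two measured steps offer some guidance. The closer one is a 7.4-fold lower number from compound 2 to compound 3 (0.87 log units; beyond the scatter), as it also changes a single substituent on this ring, but it involves methyl rather than chloro. The other, a 2.1-fold lower number from compound 1 to compound 3 (0.31 log units; beyond the scatter), exchanges the whole aryl group. Neither places a chloro on this ring, so they suggest a plausible size but do not settle the direction.

A modest fall is tentatively expected, seen as a 1.8-fold lower number from compound 3 to compound 4 (0.25 log units; within the scatter). For compound 4, the estimated half-life is 2.2 h, with an expected range of 0.7 h to 7 h.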

Compound 4, half-life: 16.3 h
The estimate for compound 4 lay 7.4-fold (0.87 log units) below the measured number; the measured number lies above the stated range.
By their numbers in this assay, from the lowest: compound 3; then compound 1; then compounds 4 and 2 (each within the scatter of the next).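

In this assay a single chloro next to the ring nitrogen gives a 4.2-fold higher number from compound 3 to compound 4 (0.62 log units; beyond the scatter), which shows that this position on the ring responds to substitution and that chloro here moves the number upward. Set against the other two aryl groups, 2-chloropyridin-3-yl gives a 2.0-fold higher number from compound 1 to compound 4 (0.31 log units; beyond the scatter) and a 1.8-fold lower number from compound 2 to compound 4 (0.25 log units; within the scatter), so chloro at this position and the methyl of 6-methylpyridin-3-yl cannot be told apart on this read-out. No measurement here accounts for the rise.

The compounds shown leave open whether another group at this position, such as fluoro, methoxy or an amine, would give a similar rise. They also leave open what chloro and methyl would give together on one ring.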